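Aryl urea series: swap on the anilino ring

This account rests on a few compounds, and the source may have more. Where it says the series, first, only, none or still open, it means among the compounds named here.

Two compounds of the series carry the shared core of compound 1, `COc1cc(NC(=O)Nc2cc(Nc3ccc(C(C)(C)C)cc3)ncn2)cc(OC)c1`, with a urea-linked aryl group varied at one end. In a functional assay on NCI-H1581 cells (Homo sapiens) for inhibition, read by MTT assay, with a stated time of 48 h, tested at 10 uM (a higher number here means more inhibition at the concentration tested (going by the name of the read-out), a lower number less inhibition), compound 1 gives 38.7%. Compound 2, `COc1cc(NC(=O)Nc2cc(Nc3ccc(OC)c(I)c3)ncn2)cc(OC)c1`, gives 43% in this assay. The one measured step, a number 4.3 percentage points higher from compound 1 to compound 2 (within the scatter), does not separate the two compounds; on the numbers shown compound 2 sits beside compound 1 rather than apart from it.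

Compound 3, `COc1cc(NC(=O)Nc2cc(Nc3cc(C)cc(F)c3)ncn2)cc(OC)c1`, is not yet measured. It differs from compound 2 by 3-fluoro-5-methylphenyl in place of 3-iodo-4-methoxyphenyl on a nitrogen on an aromatic ring. Within the data shown here, the only step that bears on this change is the one from compound 1 to compound 2, an exchange of the whole aryl group at the same place, which moved the read-out by a number 4.3 percentage points higher from compound 1 to compound 2 (within the scatter). Among the measured compounds shown here, no measured step at this position has gone beyond the scatter, so no step beyond the scatter is expected here either; the expected step is a number 3 percentage points lower from compound 2 to compound 3 (within the scatter). For compound 3 the estimate in this assay is 40%, with a range from 25% to 55%.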

Compound 3, a percentage reported as inhibition, at one concentration (the size of the read-out at that concentration, not a potency): 28.3%
Compound 3: the middle estimate sits 11.7 percentage points above what was measured; low and high end bracket the measured number.
By their numbers in this assay, from the lowest: compound 3; then compounds 1 and 2 (each within the scatter of the next).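

In this assay the aryl group on a nitrogen on an aromatic ring now moves the read-out beyond the scatter: the change shows up as a number 14.7 percentage points lower from compound 2 to compound 3 (beyond the scatter) and also as a number 10.4 percentage points lower from compound 1 to compound 3 (beyond the scatter), so the position is not indifferent to what it carries. 3-Fluoro-5-methylphenyl stands apart from both 3-iodo-4-methoxyphenyl and 4-(tert-butyl)phenyl, two groups that remain within the scatter of each other despite their different names and substitution, so the earlier step gave no sign of this separation. Nothing at hand offers an explanation for the lower number at compound 3.

Each exchange replaces the whole aryl group, so the compounds shown cannot assign the step to the fluorine, to the methyl, or to the loss of the iodine, the methoxy or the tert-butyl group. Also open, as far as these compounds go, is whether a phenyl ring carrying a carboxylic acid or a dimethylamino group at this place would read with compound 3 or with compound 1 and compound 2.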